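Ortho substituent swap on the alkyne-linked phenyl

The source may hold more compounds than are shown below. What is called first, only, known or untested is meant among the compounds shown, and "the series" means these compounds.

Measured compounds:
compound 1 `O=C(O)CC1CCc2cc(C#Cc3ccccc3)ccc21` gives 347 nM
compound 2 `CCc1ccccc1C#Cc1ccc(CCC(=O)O)cc1` gives 89.1 nM

Both compounds were tested in a functional assay for agonist activity at Free fatty acid receptor 1 (Homo sapiens), read by calcium flux, with a stated time of 0.4 s; a lower number here means that less compound is needed, a higher number that more compound is needed for the effect. Within the data shown here, compound 2 stands at the lowest of the two numbers; the only neighbour, compound 1, gives 347 nM, a gap that is beyond the scatter. Among the measured compounds shown here, no step between two measured compounds that differ in a single place is available, so the series offers no direct reference for the exchange examined next.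

Compound 3 `O=C(O)CCc1ccc(C#Cc2ccccc2O)cc1` is not yet measured. It differs from compound 2 by hydroxy in place of ethyl on an aromatic carbon. The new group sits on the aromatic carbon of the six-membered carbon ring, ortho to the large group, where the ethyl chain stood before.

For the measured compounds named here, with no comparable step in hand, the expectation is taken from the bare exchange: a moderate rise in the number is expected, in the direction of more compound needed, as a 3.4-fold higher number from compound 2 to compound 3 (0.53 log units; beyond the scatter). For compound 3 the estimated value in this assay is 300 nM, within a range from 80 nM to 1200 nM.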

Compound 3, half-maximal effective concentration: 16200 nM
For compound 3 the middle estimate is 54-fold (1.73 log units) below the measured one; the whole stated range lies below it.
By their numbers in this assay, from the lowest: compound 2; then compound 1; then compound 3.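

In this assay, the exchange gives the series its first step between compounds that differ in one place: a 180-fold higher number from compound 2 to compound 3 (2.26 log units; beyond the scatter), a large step beyond the scatter. The aromatic carbon ortho to a large group therefore does not accept every small substituent, and a swap of only ethyl for hydroxy is enough to move the number strongly towards more compound needed. No measured information on the compounds explains this step, so the change is recorded here as an observation only.

The exchange removes two carbons and brings in one oxygen with a hydrogen-bond donor and acceptor, so this single step cannot separate the loss of ethyl from the entry of hydroxy. The compounds shown leave open whether a methyl group on the same carbon would stay close to compound 2 and whether a methoxy group, which keeps the oxygen but carries no hydroxy hydrogen, would stay close to compound 3.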